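The source may report more compounds than this note shows. Statements on the series, on what has been measured and on what is new or still open speak of the compounds shown alone.

Measured so far:
compound 1, `COc1cc(OC)c2c(=O)cc(-c3ccc(OCCN4CCCC4=O)cc3)oc2c1`: 33%
compound 2, `COc1cc(OC)c2c(=O)cc(-c3ccc(OCC(O)CN4CCCC4)cc3)oc2c1`: 57%

Compound 2 stands highest of the two numbers in a functional assay (Homo sapiens) for antiproliferative activity, read by resazurin assay, with a stated time of 48 h, tested at 20 uM; a higher number here means a stronger effect of the compound at the concentration tested, a lower number a weaker effect; its nearest neighbour is compound 1, which lies a number 24 percentage points higher from compound 1 to compound 2 (beyond the scatter). Compound 3, `COc1cc(OC)c2c(=O)cc(-c3ccc(OCC(O)CO)cc3)oc2c1`, has not yet been measured. It differs from compound 2 in one place: hydroxy in place of pyrrolidin-1-yl on a saturated chain carbon, two bonds along the chain from an oxygen on a saturated carbon. Within the data shown here, the only measured step, from compound 1 to compound 2, changed the same chain but in a different way, so it bears on this step only loosely. Compound 3 shares with compound 1 the absence of a pyrrolidin-1-yl group, and that is the sole hint the data give. The step from compound 2 to compound 3 is therefore expected to be a number 22 percentage points lower from compound 2 to compound 3 (beyond the scatter), a drop beyond the scatter. For compound 3 the expected value in this assay is 35%, with a likely range from 15% to 58%.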

Compound 3, a percentage reported as inhibition, at one concentration (the size of the read-out at that concentration, not a potency): 16%
Estimate against measurement, compound 3: 19 percentage points above; measured number inside the range.
By their numbers in this assay, from the lowest: compound 3; then compound 1; then compound 2.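

In this assay, hydroxy in place of pyrrolidin-1-yl at the end of the chain gives a number 41 percentage points lower from compound 2 to compound 3 (beyond the scatter), so the group at this place strongly affects the read-out. The hydroxy that the chain keeps in both compounds does not preserve the effect on its own, and 1,2-dihydroxyethyl in place of (2-oxopyrrolidin-1-yl)methyl gives a number 17 percentage points lower from compound 1 to compound 3 (beyond the scatter), so this diol chain also falls short of the chain ending in the ring carbonyl compound. No measurement here explains these differences.

From the compounds shown here alone, whether the effect needs the pyrrolidine ring itself or would persist with another amine, such as piperidin-1-yl or open-chain dimethylamino, remains open. The separate contributions of the chain hydroxy and the ring carbonyl also remain unresolved, since compound 1 and compound 2 differ in both.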